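The compounds below may be only part of what the source reports. "The series", "measured", "known", "first", "only" and "open" are said of these compounds alone.

Compound 2 `O=C1c2ccccc2CN1c1cnc(NCc2c(F)ccc3c2CCO3)n2cnnc12` and compound 1 `CN(c1ccn(C)n1)c1cnc(NCc2c(F)ccc3c2CCO3)c2cn[nH]c(=O)c12` share the benzylamine side chain and differ in the core and the substituent on it. In a physicochemical assay for lipophilicity, using the shake flask method, in phosphate buffer, measured as octanol-water partition, with a stated time of 30 min, at pH 7.4 (a higher number here means a more lipophilic compound, a lower number a more polar compound), compound 2 gives 2.7, and compound 1 gives 2.4; the two numbers lie within the scatter of each other, so the series does not yet separate them. Compound 3 `CN(c1ncco1)c1cnc(NCc2c(F)ccc3c2CCO3)n2cnnc12` is compound 2 with the change (a group of 7 heavy atoms (4 carbon, 2 nitrogen, 1 oxygen; one five-membered aromatic ring with 2 hetero atoms) in place of a group of 10 heavy atoms (8 carbon, 1 nitrogen, 1 oxygen; one five-membered non-aromatic ring with 1 hetero atom, one six-membered aromatic ring of carbon only), on an aromatic carbon). Among the measured compounds shown here, no measured step of this kind exists. The loss of the six-membered aromatic ring of carbon only and the extra acceptors make a downward step from compound 2 to compound 3 of a number 0.90 log units lower from compound 2 to compound 3 (beyond the scatter) expected, beyond the scatter. Compound 3 is therefore estimated at 1.8, within 1.2 to 2.4.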

Compound 3, distribution coefficient: 2.1
Estimate against measurement, compound 3: 0.30 log units below, within the range that was stated.
By their numbers in this assay, from the lowest: compounds 3, 1 and 2 (each within the scatter of the next, the first and the last beyond it).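

In this assay, the first step readable at this aromatic carbon is a number 0.60 log units lower from compound 2 to compound 3 (beyond the scatter) on exchanging the two-ring group for methyl(1,3-oxazol-2-yl)amino. The substituent at this place, para to a large group, therefore moves the read-out on an unchanged core, which compound 1 and compound 2 could not show, as they differ in more than one place. No measurement available bears on the reason for this step. The step also leaves open how much belongs to the five-membered aromatic ring and how much to the methylamino link. From the compounds shown here alone, whether a morpholine or a dimethylamino group here would lie nearer compound 3 or compound 2 in this assay is also open.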